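The source may hold more compounds than are shown below. What is called first, only, known or untested is meant among the compounds shown, and "the series" means these compounds.

Measured compounds in the series:

compound 1, `Cc1cc(C(=O)O)nn1Cc1cc(Br)ccc1OCc1ccccc1`, 6.31 nM
compound 2, `Cc1cc(C(=O)Nc2ccccc2)nn1Cc1cc(Cl)ccc1OCc1ccccc1`, 39.8 nM
compound 3, `Cc1cc(C(N)=O)nn1Cc1cc(Cl)ccc1OCC(C)C`, 126 nM

In an assay on CHO-K1 cells for displacement of a labelled ligand from prostaglandin E2 receptor EP1 subtype (Homo sapiens) (a higher number here means a weaker inhibitor, a lower number a stronger inhibitor), compound 2 gives 39.8 nM, the second highest of the three numbers: compound 3 sits higher at 126 nM, beyond the scatter, and compound 1 sits lower at 6.31 nM, also beyond the scatter. Among the compounds with values here, none of the three differ in a single place, so no single-change step is available.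

Compound 4, `Cc1cc(NC(=O)C(C)C)nn1Cc1cc(Cl)ccc1OCc1ccccc1`, is not yet measured in this assay. It differs from compound 2 by (isopropylcarbonyl)amino in place of phenylcarbamoyl on an aromatic carbon. Within the data shown here, with no comparable step measured, the estimate for compound 4 assumes a modest weakening, a 2.5-fold higher number from compound 2 to compound 4 (0.40 log units; beyond the scatter), possibly beyond the scatter. Compound 4 is therefore expected near 100 nM, within 30 nM to 400 nM.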

Compound 4, half-maximal inhibitory concentration: 25.1 nM
Beside the measured number, compound 4's estimate is 4.0-fold (0.60 log units) above it; the whole stated range lies above it.
By their numbers in this assay, from the lowest: compound 1; then compounds 4 and 2 (each within the scatter of the next); then compound 3.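

In this assay, (isopropylcarbonyl)amino in place of phenylcarbamoyl on this aromatic carbon gives a 1.6-fold lower number from compound 2 to compound 4 (0.20 log units; within the scatter). This position therefore accepts a change from a group with a six-membered aromatic ring to one with no ring, without a shift beyond the scatter, at least in this pair. No measurement available here explains this tolerance.

From the compounds shown here alone, what a simple amine or a longer acyl chain would give at this carbon stays open. Compound 1 and compound 3 differ from this pair in more than one place, so they cannot show whether the tolerance carries over to other substituents on the shared core.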